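The source may hold more compounds than are shown below. What is called first, only, known or untested is meant among the compounds shown, and "the series" means these compounds.

Working notes on the series. The shared core carries an acetyl group and a variable aryl group on a saturated ring carbon; compound 1 `COc1cc(C2=NN(C(C)=O)C(c3c(Cl)cccc3Cl)O2)cc(OC)c1OC`, compound 2 `COc1cc(C2=NN(C(C)=O)C(c3cccc(OC)c3OC)O2)cc(OC)c1OC` and compound 3 `COc1cc(C2=NN(C(C)=O)C(c3ccccc3F)O2)cc(OC)c1OC` have been measured in a functional assay on PC-3 cells (Homo sapiens) for antiproliferative activity, read by MTT assay, tested at 5 uM; on this read-out higher numbers stand for a stronger effect at the one concentration tested and lower numbers for a weaker effect. Compound 1 gives -2.2%, compound 2 gives 58.2% and compound 3 gives 31.6%. Compound 3 therefore stands second highest of the three: the step of a number 33.8 percentage points higher from compound 1 to compound 3 (beyond the scatter) and the step of a number 26.6 percentage points lower from compound 2 to compound 3 (beyond the scatter) both lie beyond the scatter. The further change to compound 4 `COc1cc(C2=NN(C(C)=O)C(c3cccc(C(F)(F)F)c3)O2)cc(OC)c1OC` is 3-(trifluoromethyl)phenyl in place of 2-fluorophenyl on a saturated ring carbon. All three measured steps change the aryl group on the same saturated ring carbon, and they were large, a number 60.4 percentage points higher from compound 1 to compound 2 (beyond the scatter) and a number 33.8 percentage points higher from compound 1 to compound 3 (beyond the scatter), or modest, a number 26.6 percentage points lower from compound 2 to compound 3 (beyond the scatter), so swaps at this carbon can move this assay markedly in either direction. Within the data shown here, no measured compound carries a trifluoromethyl group, so the direction cannot be read from the data; a step of a number 3.6 percentage points lower from compound 3 to compound 4 (within the scatter) is expected, with wide uncertainty. For compound 4 the estimate in this assay is 28%, ranging from 0% to 58%.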

Compound 4, a percentage reported as inhibition, at one concentration (the size of the read-out at that concentration, not a potency): 43.6%
Compound 4: the middle estimate sits 15.6 percentage points below what was measured; low and high end bracket the measured number.
By their numbers in this assay, from the lowest: compound 1; then compound 3; then compound 4; then compound 2.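

In this assay the change to 3-(trifluoromethyl)phenyl gives a number 12 percentage points higher from compound 3 to compound 4 (beyond the scatter) and shows that the two fluorine-bearing aryl groups on this saturated ring carbon do not read alike. The same group gives a number 14.6 percentage points lower from compound 2 to compound 4 (beyond the scatter) and also a number 45.8 percentage points higher from compound 1 to compound 4 (beyond the scatter) so it falls between the 2,3-dimethoxyphenyl and 2,6-dichlorophenyl groups, and the three halogen-bearing aryl groups now stand apart with none reaching compound 2. No available evidence accounts for these differences.

The change from compound 3 to compound 4 alters both the substituent and where it sits on the phenyl ring, so the two contributions cannot be separated. As far as these compounds go, how an aryl group carrying an amine or a carboxylic acid would behave on this carbon remains open.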